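The source may hold more compounds than are shown below. What is called first, only, known or untested is meant among the compounds shown, and "the series" means these compounds.

Measured so far in a functional assay on HeLa cells (Homo sapiens) for cytotoxicity, read by MTT assay; on this read-out lower numbers stand for stronger inhibition and higher numbers for weaker inhibition:
compound 1 `CC(C)[C@@H](NC(=S)NCc1ccccc1)c1nc2ccccc2[nH]1` gives 12300 nM;
compound 2 `CC(C)C[C@@H](NC(=S)Nc1cc(C(F)(F)F)cc(C(F)(F)F)c1)c1nc2ccccc2[nH]1` gives 10400 nM;
compound 3 `CC(C)C[C@H](NC(=S)Nc1cc(C(F)(F)F)cc(C(F)(F)F)c1)c1nc2ccccc2[nH]1` gives 18100 nM.

Of these three numbers compound 2 shows the smallest, yet the gap to compound 1 and the step of a 1.7-fold higher number from compound 2 to compound 3 (0.24 log units; within the scatter) both lie within the scatter, so the three cannot be told apart. Compound 4 `C[C@@H](NC(=S)Nc1cc(C(F)(F)F)cc(C(F)(F)F)c1)c1nc2ccccc2[nH]1`, not yet measured, differs from compound 2 by hydrogen in place of isopropyl on a saturated chain carbon, two bonds along the chain from an amide-type nitrogen and an aromatic carbon. For the measured compounds named here, the only measured step, a 1.7-fold higher number from compound 2 to compound 3 (0.24 log units; within the scatter), rests on the fact that compounds 2 and 3 differ only in the configuration as drawn and says nothing about shortening the side chain; no measured pair speaks to that change. No shift beyond the scatter is therefore expected. Compound 4 is estimated at 14000 nM, within 5000 nM to 40000 nM, the expected step being a 1.3-fold higher number from compound 2 to compound 4 (0.13 log units; within the scatter).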

Compound 4, half-maximal inhibitory concentration: 16100 nM
Beside the measured number, compound 4's estimate is 1.2-fold (0.06 log units) below it; measured number inside the range.
By their numbers in this assay, from the lowest: compounds 2, 1, 4 and 3 (each within the scatter of the next).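

In this assay, hydrogen in place of isopropyl on this saturated chain carbon, which turns isobutyl into methyl, gives a 1.5-fold higher number from compound 2 to compound 4 (0.19 log units; within the scatter) and so no shift that can be told from the scatter. The earlier step concerned configuration only, whereas this pair shows that this reduction in side-chain size leaves the number within the scatter. Nothing available bears on why this is so.

Still open, as far as these compounds go, is whether a longer chain or an amine at this position would move the number beyond the scatter.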